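Swapping the Sulfonamide Aryl Group at the Assay Limit

The compounds below may be only part of what the source reports. "The series", "measured", "known", "first", "only" and "open" are said of these compounds alone.

Compound 1, `C[C@@H](Cn1ccc(-c2ccc(C#N)c(Cl)c2)n1)NC(=O)c1ccccc1F`: > 30000 nM
Compound 2, `CC(=O)c1ccc(S(=O)(=O)N[C@@H](C)Cn2ccc(-c3ccc(C#N)c(Cl)c3)n2)cc1`: > 30000 nM

Of the compounds shown here, two have so far been tested in an ADME assay on PC-3 cells (Homo sapiens) for cytotoxicity, read by CCK-8 assay, with a stated time of 6 days; a lower number here means a stronger inhibitor, a higher number a weaker inhibitor. For compound 1 the value > 30000 nM is a limit of the assay. For compound 2 the value > 30000 nM is likewise a limit. Compound 2 therefore stands at the limit of > 30000 nM in this assay, at which 2 of the 2 values shown sit; on the numbers shown nothing separates it from compound 1, and there is no measured step between compounds that differ in a single place to lean on.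

Compound 3, `C[C@@H](Cn1ccc(-c2ccc(C#N)c(Cl)c2)n1)NS(=O)(=O)c1cn(C)cn1`, has not yet been measured. It differs from compound 2 in one place: 1-methyl-1H-imidazol-4-yl in place of 4-acetylphenyl on a sulfonyl sulfur. Going by the values given here, the only guide is that compound 2 gives > 30000 nM in this assay, a limit. No step beyond the usual scatter is expected, and no direction can be claimed from a limit alone.

Compound 3 is expected to give 40000 nM in this assay, within the range 10000 nM to 150000 nM, most likely reported again as a limit. The step that the limit leaves unreadable from compound 2 to compound 3 that this estimate means is expected to be none beyond the scatter.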

Compound 3, half-maximal inhibitory concentration: > 30000 nM
Compound 3 ended at the assay's limit (the forecaster's own chance of this, stated with the estimate: 80%); the middle value is on the limit's open side.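

Going by these compounds alone, no step from compound 2 to compound 3, or from compound 1 to compound 3, can be read, because all three compounds give a limit of the assay rather than a number: the limit of > 30000 nM in this assay, at which 3 of the 3 values shown sit.

Still open, on these data alone, is whether swapping 4-acetylphenyl for 1-methyl-1H-imidazol-4-yl changes the result in this assay at all.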